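A few compounds are considered here, and "the series" means these few. Any claim that something is new, unique, unknown or untested is made for them only; others in the source may bear on it.

Measured so far in an ADME assay on THP-1 cells (Homo sapiens) for cytotoxicity; a higher number here means that more compound is tolerated, a lower number that less compound is tolerated:
- compound 1, `CN(C)CCNc1c(-c2ccccn2)nc2ccccn12`, gives > 50000 nM.
- compound 2, `COc1ccc(Nc2c(-c3ccccn3)nc3ccc(C)cn23)cc1`, gives 10700 nM.

The result of compound 1 is not a number but a limit: compound 1 is recorded as > 50000 nM, the point where (the limit of > 50000 nM in this assay, at which 1 of the 2 values shown sits). Compound 2, which carries a methoxyphenyl group on the ring nitrogen and a methyl on its core, gives a real value in this assay, 10700 nM, so compound 2 is tolerated less well than compound 1. Going by the values given here, no pair of these two compounds differs at a single place, so no single step can be read from them; their two values can only be set side by side.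

Compound 3, `COc1ccccc1Nc1c(-c2ccccn2)nc2ccccn12`, is compound 1 with one change: 2-methoxyphenyl in place of 2-(dimethylamino)ethyl on a nitrogen on an aromatic ring. With compound 1 sitting at the limit, any expected step in this assay can only run downward. Compound 3 is expected to land near 15000 nM, within the range 5000 nM to 50000 nM. That estimate means an expected downward step from compound 1 to compound 3 of an at least 3.3-fold lower number from compound 1 to compound 3 (0.52 log units; beyond the scatter), beyond the usual scatter, guided by compound 2 and its value 10700 nM with a related methoxyphenyl group.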

Compound 3, half-maximal cytotoxic concentration: > 50000 nM
Compound 3 gave a limit, no number; the forecaster's own chance of this, stated with the estimate: 20%; middle value at least 3.3-fold (0.52 log units) from the limit.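

In this assay compound 3 gives > 50000 nM as a limit and not a number. Going by these compounds alone, compound 1 also stands at a limit, so no step from compound 1 to compound 3 can be read: the limit of > 50000 nM in this assay, at which 2 of the 3 values shown sit. On these data alone, how far either compound lies beyond that limit, and what swapping 2-(dimethylamino)ethyl for 2-methoxyphenyl does to the tolerated concentration, remains open.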